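The compounds below may be only part of what the source reports. "The series", "measured", "known", "first", "only" and "open" are said of these compounds alone.

Measured compounds:
- Compound 1, `CCC(=O)Nc1ccc(S(=O)(=O)Oc2ccccc2I)cc1`: 7200 nM
- Compound 2, `CCCCCC(=O)Nc1ccc(S(=O)(=O)Oc2ccccc2I)cc1`: 9600 nM
- Compound 3, `CCCNC(=O)Nc1ccc(S(=O)(=O)Oc2ccccc2C(C)C)cc1`: 680 nM

In a functional assay on HT-1080 cells (Homo sapiens) for antiproliferative activity, read by sulforhodamine B assay, with a stated time of 48 h (a higher number here means a weaker inhibitor, a lower number a stronger inhibitor), compound 3 gives the lowest number of the three; compound 1 gives 7200 nM and compound 2 gives 9600 nM, both beyond the scatter above it. Compound 4, `CCCNC(=O)Nc1ccc(S(=O)(=O)Oc2ccccc2I)cc1`, keeps the urea of compound 3 and differs from it by iodo in place of isopropyl on an aromatic carbon. Among the compounds with values here, no measured step covers this exchange: the only step on hand, a 1.3-fold higher number from compound 1 to compound 2 (0.12 log units; within the scatter), concerns the chain on the amide side and bears on it only in showing that the chain there changes little. Compounds 1 and 2 carry the iodo group but also an amide in place of the urea, so their higher numbers cannot be assigned to the iodo group alone. Within the data shown here, with no direct precedent, the estimate for compound 4 is placed between compound 3 and the iodo amides, a step of a 2.2-fold higher number from compound 3 to compound 4 (0.34 log units; beyond the scatter), giving an expected 1500 nM with a range from 400 nM to 6000 nM.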

Compound 4, half-maximal inhibitory concentration: 700 nM
For compound 4 the middle estimate is 2.1-fold (0.33 log units) above the measured one; the measured number falls inside the stated range.
By their numbers in this assay, from the lowest: compounds 3 and 4 (each within the scatter of the next); then compounds 1 and 2 (each within the scatter of the next).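

In this assay, iodo in place of isopropyl on this aromatic carbon, ortho to a large group, gives a 1.0-fold higher number from compound 3 to compound 4 (0.01 log units; within the scatter) and so leaves the number unchanged within the scatter, a comparison that compounds 1 and 2 could not give. With the iodo group held fixed, propylamino in place of pentyl on the carbonyl carbon gives a 14-fold lower number from compound 2 to compound 4 (1.14 log units; beyond the scatter) and propylamino in place of ethyl gives a 10-fold lower number from compound 1 to compound 4 (1.01 log units; beyond the scatter) so the large differences among these compounds go with the change at the carbonyl carbon, not with the iodo group. Nothing available here accounts for these numbers.

As far as these compounds go, whether this aromatic carbon would take other groups, such as a methoxy group, a chlorine or a carboxylic acid, stays open. Also open, from the compounds shown here alone, is how a longer chain or an amine on the urea would read, and whether isopropyl paired with an amide would follow the iodo amides.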